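The compounds below may be only part of what the source reports. "The series", "measured", "known", "first", "only" and "open" are said of these compounds alone.

Compound 1 `CN(C(=S)SCc1ccc(C(=O)Nc2ccccc2N)cc1)c1cccnc1`, compound 2 `N#Cc1ccc(N2CCN(C(=S)SCc3ccc(C(=O)Nc4ccccc4N)cc3)CC2)cc1` and compound 3 `Nc1ccccc1NC(=O)c1ccc(CSC(=S)N2CCN(Cc3ccncc3)CC2)cc1` share one core and have each been tested in a functional assay on MGC-803 cells (Homo sapiens) for antiproliferative activity, read by CCK-8 assay, with a stated time of 72 h, tested at 2 uM; on this read-out higher numbers stand for a stronger effect at the one concentration tested and lower numbers for a weaker effect. Compound 1 gives 46.1%, compound 2 gives 34.5% and compound 3 gives 18.4%, which leaves compound 3 lowest of the three, with compound 2 nearest and compound 1 furthest. Going by the values given here, the one step among them is a number 16.1 percentage points lower from compound 2 to compound 3 (beyond the scatter), a modest drop beyond the scatter. Compound 4 `Nc1ccccc1NC(=O)c1ccc(CSC(=S)N2CCN(c3ccncc3)CC2)cc1` has not yet been measured in this assay. It differs from compound 3 by pyridin-4-yl in place of (pyridin-4-yl)methyl on an amine nitrogen in a ring. Among the compounds with values here, the only measured step at this position is the one from compound 2 to compound 3, where 4-cyanophenyl on the amine nitrogen in the ring gave way to (pyridin-4-yl)methyl; compound 4 instead carries pyridin-4-yl on that nitrogen, so the comparison is loose and no direct step to a close analogue exists. A modest rise is therefore expected, a number 7.6 percentage points higher from compound 3 to compound 4 (within the scatter), though the number could also stay within the scatter. For compound 4 the expected value is 26%, with a range from 12% to 42%.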

Compound 4, a percentage reported as inhibition, at one concentration (the size of the read-out at that concentration, not a potency): 64.8%
For compound 4 the middle estimate is 38.8 percentage points below the measured one; measured number above the stated range.
By their numbers in this assay, from the lowest: compound 3; then compound 2; then compound 1; then compound 4.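

In this assay, pyridin-4-yl in place of (pyridin-4-yl)methyl on the amine nitrogen in the ring gives a number 46.4 percentage points higher from compound 3 to compound 4 (beyond the scatter), so the read-out at this position depends strongly on how the pyridine ring is attached to that nitrogen, which the earlier step could not show. Pyridin-4-yl in place of 4-cyanophenyl on the same nitrogen gives a number 30.3 percentage points higher from compound 2 to compound 4 (beyond the scatter), so the two groups attached there through a ring atom also differ widely, and the earlier step alone did not reveal this. Nothing available here explains the size of these steps.

As far as these compounds go, it remains open whether the high reading is specific to pyridin-4-yl or would also appear with pyridin-3-yl, plain phenyl or a longer chain such as 2-(pyridin-4-yl)ethyl on that nitrogen. A reading at one concentration also leaves the potency of these compounds open.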